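Indole-linked phenyl series: para substituent swap toward trifluoromethoxy

A few compounds are considered here, and "the series" means these few. Any claim that something is new, unique, unknown or untested is made for them only; others in the source may bear on it.

Measured so far:
compound 1, `Fc1ccc(-c2cc3ccccc3[nH]2)cc1`, 21.8%
compound 2, `Brc1ccc(-c2cc3ccccc3[nH]2)cc1`, 4.8%
compound 3, `CN(C)c1ccc(-c2cc3ccccc3[nH]2)cc1`, 0%

Three compounds share one core and differ only in the group on the six-membered aromatic ring of carbon only. In an assay on isolated protein for inhibition of Aromatase (Homo sapiens), read by fluorescence, using NADPH, with a stated time of 30 min, tested at 50 uM (on this read-out lower numbers stand for less inhibition and higher numbers for more inhibition at the one concentration tested (going by the name of the read-out)), compound 1 gives 21.8%, compound 2 gives 4.8% and compound 3 gives 0%. Compound 3 holds the lowest of the three numbers; its gap to compound 2 lies within the scatter, while the step of a number 21.8 percentage points lower from compound 1 to compound 3 (beyond the scatter) lies beyond it. The measured steps run in one direction: a number 17 percentage points lower from compound 1 to compound 2 (beyond the scatter) and a number 21.8 percentage points lower from compound 1 to compound 3 (beyond the scatter) both lower the read-out, and a number 4.8 percentage points lower from compound 2 to compound 3 (within the scatter) lies within the scatter.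

Compound 4, `FC(F)(F)Oc1ccc(-c2cc3ccccc3[nH]2)cc1`, differs from compound 3 as follows: trifluoromethoxy in place of dimethylamino on an aromatic carbon. For the measured compounds named here, no measured step exchanges dimethylamino for trifluoromethoxy, so the nearest guidance is that every change away from fluoro has lowered this assay and that bromo and dimethylamino sit close together. The expectation is therefore for a small rise at most, a number 8 percentage points higher from compound 3 to compound 4 (within the scatter), not clearly beyond the scatter, with compound 1 marking the upper bound seen so far. Compound 4 is estimated at 8%, within 0% to 25%.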

Compound 4, a percentage reported as inhibition, at one concentration (the size of the read-out at that concentration, not a potency): 1.86%
Compound 4: the middle estimate sits 6.1 percentage points above what was measured; the range from low to high includes it.
By their numbers in this assay, from the lowest: compounds 3, 4 and 2 (each within the scatter of the next); then compound 1.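

In this assay trifluoromethoxy at this position cannot be told apart from the two groups already at the low end, as the exchange for dimethylamino gives a number 1.9 percentage points higher from compound 3 to compound 4 (within the scatter) and the exchange for bromo gives a number 2.9 percentage points lower from compound 2 to compound 4 (within the scatter) in the same read-out. For the compounds shown here, exchanging fluoro for trifluoromethoxy gives a number 19.9 percentage points lower from compound 1 to compound 4 (beyond the scatter) and so repeats what bromo and dimethylamino showed, which leaves fluoro as the one group of these four that stands clear of the other three, with no compound here going against that grouping. Nothing available accounts for this separation or for the close agreement of three different groups.

The compounds shown leave open whether any group at this position can take the read-out clearly past compound 1 with its 21.8% in this assay at the one concentration tested. They also leave open whether chloro, a primary amine or a carboxylic acid in this place would fall with fluoro or with the other three, and how these compounds would compare as true potencies rather than as single-concentration readings.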